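The compounds below may be only part of what the source reports. "The series", "measured", "known", "first", "only" and "open" are said of these compounds alone.

Measured compounds in a functional assay on the whole organism (B cells) with Mus musculus as the target; a lower number here means a smaller maximal response, a higher number a larger maximal response:
compound 1 `C=CCn1c(=O)n(C2C=CC(CO)O2)c2nc(N)nc(O)c21` gives 45%
compound 2 `Nc1nc(O)c2c(n1)n(C1OC(CO)[C@@H](O)[C@H]1O)c(=O)n2Cc1ccc(Cl)cc1` gives 15%
compound 3 `C=CCn1c(=S)n(C2OC(COCc3ccccc3)[C@H]3OC(C)(C)O[C@@H]23)c2nc(N)nc(O)c21` gives 77%

Of the three numbers, compound 2 holds the lowest. Its nearest neighbour is compound 1, whose number lies higher by an amount beyond the scatter, and the furthest is compound 3, whose number lies higher still, also beyond the scatter. No two of the three compounds differ in only one place, so none of these gaps can be tied to a single structural change.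

Compound 4 `N#Cc1cccc(Cn2c(=O)n(C3OC(CO)[C@@H](O)[C@H]3O)c3nc(N)nc(O)c32)c1` has not yet been measured in this assay. It differs from compound 2 in one place: 3-cyanophenyl in place of 4-chlorophenyl on a saturated chain carbon bound to an aromatic nitrogen. The group that leaves and the group that enters are each a single six-membered aromatic ring of carbon only, and both sit on a saturated chain carbon bound to an aromatic nitrogen; the entering group carries a triple bond outside the ring and one hydrogen-bond acceptor where the leaving group carried none.

Within the data shown here, no measured pair shows what such a change does in this assay. The account therefore expects a small step, within the scatter or only slightly upward, from compound 2 to compound 4, that is a number 7 percentage points higher from compound 2 to compound 4 (within the scatter). For compound 4 the expected value is 22%, with a range from 8% to 45%.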

Compound 4, largest response reached (reported as maximal response), in percent of the reference or control that the assay uses: 16%
Compound 4: the middle estimate sits 6 percentage points above what was measured, and the stated range covers the measured number.
By their numbers in this assay, from the lowest: compounds 2 and 4 (each within the scatter of the next); then compound 1; then compound 3.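

In this assay, among these compounds, the first change that can be read at a single place, 4-chlorobenzyl to 3-cyanobenzyl on a saturated chain carbon bound to an aromatic nitrogen, gives a number 1 percentage points higher from compound 2 to compound 4 (within the scatter) and so leaves the maximal response within the scatter. Among the compounds shown here, at this position, then, the exchange of 4-chlorophenyl for 3-cyanophenyl, which brings in a triple bond outside the ring and a hydrogen-bond acceptor, does not produce a step beyond the scatter, something the earlier compounds, none of which differed in only one place, could not show. No measurement here offers an explanation for this outcome.

The change swaps the chlorine for a nitrile and moves the substituent on the ring in one go, so the compounds shown cannot say whether either alteration alone would leave the response as it stands, or whether the two simply offset each other; 3-chlorobenzyl and 4-cyanobenzyl would separate them. Also open, from the compounds shown here alone, is whether this position would respond to a different kind of group, such as a plain benzyl, a carboxylic acid or an amine on the ring, or a longer chain between the ring and the aromatic nitrogen.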